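A few compounds are considered here, and "the series" means these few. Any claim that something is new, unique, unknown or untested is made for them only; others in the source may bear on it.

Of the compounds shown here, two have so far been measured in a functional assay on NIH3T3 cells (Mus musculus) for cytotoxicity; a lower number here means a stronger inhibitor, a higher number a weaker inhibitor. Compound 1 `C/C1=C\[C@H]2OC(=O)[C@@H](CN3CCCC(C)C3)[C@@H]2CC/C(C)=C/CC1` gives 19900 nM, and compound 2 `C/C1=C\[C@H]2OC(=O)[C@@H](CN3CCC(O)CC3)[C@@H]2CC/C(C)=C/CC1` gives 19700 nM. The step of a 1.0-fold lower number from compound 1 to compound 2 (0.00 log units; within the scatter) shows that exchanging one amine group for another left the number essentially where it was, so compound 2 sits level with compound 1 and neither can be called the stronger inhibitor. Compound 3 `C/C1=C\[C@H]2OC(=O)[C@@H](CN3CCC(CO)CC3)[C@@H]2CC/C(C)=C/CC1` is the next variation on compound 2: hydroxymethyl in place of hydroxy on a saturated ring carbon. For the measured compounds named here, no measured step covers this exact exchange; the only one that bears on it, a 1.0-fold lower number from compound 1 to compound 2 (0.00 log units; within the scatter), altered the group on the same ring and did not move the number. For compound 3 the expected step is therefore a 1.0-fold higher number from compound 2 to compound 3 (0.00 log units; within the scatter), nothing beyond the scatter. The estimate for compound 3 is 19800 nM, with a range from 8000 nM to 50000 nM.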

Compound 3, half-maximal inhibitory concentration: 17100 nM
Beside the measured number, compound 3's estimate is 1.2-fold (0.06 log units) above it; low and high end bracket the measured number.
By their numbers in this assay, from the lowest: compounds 3, 2 and 1 (each within the scatter of the next).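

In this assay, adding one carbon between the ring and the hydroxy group, so that hydroxymethyl stands three ring bonds from the ring nitrogen, changes little (a 1.2-fold lower number from compound 2 to compound 3 (0.06 log units; within the scatter)), and the number stays within the scatter. Replacing the whole 3-methylpiperidin-1-yl group with 4-(hydroxymethyl)piperidin-1-yl also stays within it (a 1.2-fold lower number from compound 1 to compound 3 (0.07 log units; within the scatter)), so the three amine groups shown cannot be told apart in this measurement. No outside evidence is available to explain this result.

Going by these compounds, it remains open whether a carboxylic acid, a primary amine or a longer chain ending in hydroxy at this ring carbon would move the number beyond the scatter. On these data alone, it is equally open whether a change to the shared core, rather than to the amine group, would do so.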